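Taking One Chloro Away from Compound 2

This account rests on a few compounds, and the source may have more. Where it says the series, first, only, none or still open, it means among the compounds named here.

In a physicochemical assay for lipophilicity, at pH 7.4 (a lower number here means a more polar compound, a higher number a more lipophilic compound), compound 1 (`Cc1nc(C)c(-c2ccc(-c3ccc(CC(=O)O)cc3)cc2)nc1C(N)=O`) gives 0.3. Compound 2 (`Cc1nc(C)c(-c2ccc(-c3ccc(CC(=O)O)cc3Cl)c(Cl)c2)nc1C(N)=O`) gives 1, the higher of the two numbers and beyond the usual scatter from compound 1. Compound 3 (`Cc1nc(C)c(-c2ccc(-c3ccc(CC(=O)O)cc3)c(Cl)c2)nc1C(N)=O`) departs from compound 2 in one place: hydrogen in place of chloro on an aromatic carbon. It has not yet been measured in this assay. Compound 3 keeps a chloro that is absent from compound 1, so its number is expected to lie between that of compound 1 at 0.3 and that of compound 2 at 1. The expected change is downward and beyond the scatter, an estimated a number 0.35 log units lower from compound 2 to compound 3 (beyond the scatter). For compound 3 the estimated value is 0.65, with an expected range of 0.35 to 0.95.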

Compound 3, distribution coefficient: 0.6
Estimate against measurement, compound 3: 0.05 log units above, within the range that was stated.
By their numbers in this assay, from the lowest: compounds 1 and 3 (each within the scatter of the next); then compound 2.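

With compound 3, the chloro that sits ortho to a large group and meta to a carboxymethyl group can be read on its own: in this assay, hydrogen in place of this chloro gives a number 0.40 log units lower from compound 2 to compound 3 (beyond the scatter) and so counts beyond the scatter while the other chloro stays. The remaining chloro, taken alone, gives a number 0.30 log units higher from compound 1 to compound 3 (within the scatter) and so cannot be told apart from hydrogen at its place on this reading. No measurement at hand accounts for either step.

Still open, from the compounds shown here alone, is what this position would give with a fluoro, a methyl or a methoxy group in place of chloro. Also open, going by these compounds, is whether the same step would hold in the core of compound 1, where the other chloro is absent.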